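A few compounds are considered here, and "the series" means these few. Any claim that something is new, unique, unknown or untested is made for them only; others in the source may bear on it.

Among the compounds with values here, in a functional assay on BT-474 cells (Homo sapiens) for inhibition, read by fluorescence, with a stated time of 72 h (a lower number here means a stronger inhibitor of growth, a higher number a weaker inhibitor of growth), three compounds sharing one core have numbers so far. Compound 1 (`N[C@H]1CC[C@H](Nc2nc(Nc3ccc(Cl)cc3)c3ncn(C4CCCCC4)c3n2)CC1`) gives 4100 nM, compound 2 (`COc1ccc(Cn2cnc3c(Nc4cccc(Cl)c4)nc(N[C@H]4CC[C@H](N)CC4)nc32)cc1`) gives 8200 nM and compound 3 (`CCCCCCn1cnc2c(Nc3ccc(O)cc3)nc(N[C@H]3CC[C@H](N)CC3)nc21`) gives 7700 nM. Compound 2 therefore stands level with the other two: all three numbers lie within the usual scatter of repeated measurements, so they cannot be ranked.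

Compound 4 (`CC(C)CCn1cnc2c(Nc3cccc(Cl)c3)nc(N[C@H]3CC[C@H](N)CC3)nc21`) has not been measured yet. It differs from compound 2 in one place, on a saturated chain carbon bound to an aromatic nitrogen: isobutyl in place of 4-methoxyphenyl on a saturated chain carbon bound to an aromatic nitrogen. Read one bond further out, 4-methoxybenzyl gives way to isopentyl, so a ring is replaced by an open chain.

Within the data shown here, no two measured compounds differ in one place only, so no direct step shows what such a swap does in this assay. The closest hint is indirect. Compound 3 also has an open chain there and gives 7700 nM, while compound 2 gives 8200 nM. These two lie within the scatter of each other, although they differ elsewhere as well. No change beyond the scatter is expected, in either direction. The expected step of a 1.3-fold lower number from compound 2 to compound 4 (0.10 log units; within the scatter) is small. Compound 4 is estimated at 6500 nM, with a range of 3200 nM to 13000 nM.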

Compound 4, concentration for 50% growth inhibition: 3800 nM
For compound 4 the middle estimate is 1.7-fold (0.23 log units) above the measured one; the range from low to high includes it.
By their numbers in this assay, from the lowest: compounds 4, 1, 3 and 2 (each within the scatter of the next, the first and the last beyond it).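

Within the data shown here, replacing 4-methoxyphenyl with isobutyl on a saturated chain carbon bound to an aromatic nitrogen gives a 2.2-fold lower number from compound 2 to compound 4 (0.33 log units; beyond the scatter) in this assay and provides the first direct reading of a single change in this set. The step is modest, but it shows that this place can affect the read-out and that the 4-methoxybenzyl ring is not needed for growth inhibition at this level: the open isopentyl chain, with no ring and fewer heavy atoms, gives the lower number. Nothing available here accounts for the size or direction of this step.

The ring and the methoxy oxygen leave together in this one change, so the pair cannot separate their contributions; a plain benzyl group, which keeps the ring and lacks the oxygen, would address that question. The compounds shown also leave open how a chain ending in an amine or a carboxylic acid would read at this place, and whether the same swap would give a similar step with a different group on the rest of the core.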